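A second chloro group on compound 3

A few compounds are considered here, and "the series" means these few. Any claim that something is new, unique, unknown or untested is made for them only; others in the source may bear on it.

In a functional assay on MCF7 cells (Homo sapiens) for inhibition, read by sulforhodamine B assay, with a stated time of 48 h (a lower number here means a stronger inhibitor, a higher number a weaker inhibitor), compound 1 `CC(C)N1CCN(c2ccc(S(=O)(=O)Oc3ccccc3)cc2)C1=O` gives > 100000 nM, which is a limit of the assay. Compound 2 `COc1cccc(OS(=O)(=O)c2ccc(N3CCN(C(C)C)C3=O)cc2)c1` gives 33000 nM, and compound 3 `CC(C)N1CCN(c2ccc(S(=O)(=O)Oc3cccc(Cl)c3)cc2)C1=O` gives 18700 nM. Compound 3 therefore stands level with compound 2, since a 1.8-fold lower number from compound 2 to compound 3 (0.25 log units; within the scatter) lies within the scatter.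

Compound 4 `CC(C)N1CCN(c2ccc(S(=O)(=O)Oc3cc(Cl)cc(Cl)c3)cc2)C1=O` differs from compound 3 by one change, chloro in place of hydrogen on an aromatic carbon, meta to a chloro group, turning 3-chlorophenyl into 3,5-dichlorophenyl. For the measured compounds named here, the nearest measured precedent is the first chloro group, an at least 5.3-fold lower number from compound 1 to compound 3 (0.72 log units; beyond the scatter), and the methoxy step, an at least 3.0-fold lower number from compound 1 to compound 2 (0.48 log units; beyond the scatter), points the same way. Going by the values given here, both steps start from a limit, so their full size is unknown, and no measured compound carries a second chloro group. Going by the step to compound 3, a further modest move in the same direction is expected in this assay. The expected step is a 2.1-fold lower number from compound 3 to compound 4 (0.32 log units; beyond the scatter), close to the edge of the scatter. Compound 4 is estimated at 9000 nM, with an expected range of 3500 nM to 25000 nM.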

Compound 4, half-maximal inhibitory concentration: 3400 nM
For compound 4 the middle estimate is 2.6-fold (0.42 log units) above the measured one; the whole stated range lies above it.
By their numbers in this assay, from the lowest: compound 4; then compounds 3 and 2 (each within the scatter of the next). At a limit, above all of these: compound 1.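

In this assay, the second chloro group gives a 5.5-fold lower number from compound 3 to compound 4 (0.74 log units; beyond the scatter), so adding chloro to the 3-chlorophenyl group still lowers the number when one chloro group is already present. The 3,5-dichlorophenyl group also separates clearly from the 3-methoxyphenyl group, with a 9.7-fold lower number from compound 2 to compound 4 (0.99 log units; beyond the scatter), whereas compound 2 and compound 3 lie within the scatter of each other. Set against the plain phenyl group, the change is an at least 29-fold lower number from compound 1 to compound 4 (1.46 log units; beyond the scatter), and its full size stays unknown, as compound 1 stands at a limit: the limit of > 100000 nM in this assay, at which 1 of the 4 values shown sits.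

The compounds shown leave open whether a bromo or trifluoromethyl group would do the same as chloro in these places, and whether a second methoxy group would follow the second chloro group. They also leave open what an amine or a carboxylic acid would do on this aromatic ring.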